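A few compounds are considered here, and "the series" means these few. Any claim that something is new, unique, unknown or untested is made for them only; others in the source may bear on it.

Measured so far:
compound 1 `COc1cc(Cl)cc(-c2nn(-c3cccc(NC(=O)Nc4cc(C(F)(F)F)cc(C(F)(F)F)c4)c3)cc2-c2ccncc2)c1`; in a functional assay on NCI-H522 cells (Homo sapiens) for inhibition, read by sulforhodamine B assay, with a stated time of 48 h, tested at 0.1 uM (on this read-out lower numbers stand for a stronger effect and higher numbers for a weaker effect at the one concentration tested), compound 1 gives 80%.
compound 2 `COc1cc(Cl)cc(-c2nn(-c3cccc(NC(=O)Nc4ccc(Cl)c(Cl)c4)c3)cc2-c2ccncc2)c1`; in this assay compound 2 gives 53%.

Compound 2 stands lowest of the two numbers; its nearest neighbour is compound 1, whose number lies higher by an amount beyond the usual scatter. Compound 3 `COc1cc(Cl)cc(-c2nn(-c3cccc(NC(=O)Nc4cccc(C(F)(F)F)c4)c3)cc2-c2ccncc2)c1` has not yet been measured in this assay. It differs from compound 2 in one place: 3-(trifluoromethyl)phenyl in place of 3,4-dichlorophenyl on an amide-type nitrogen. No step between two measured compounds isolates this change, so the expectation rests on the two numbers shown. Since compound 1, which carries two trifluoromethyl groups on its outer ring, gives 80%, a shift toward a weaker effect is anticipated. The step of a number 13 percentage points higher from compound 2 to compound 3 (beyond the scatter) is expected to go toward a higher number, probably of a size beyond the scatter. Compound 3 is expected to give 66%, within 46% to 88%.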

Compound 3, a percentage reported as activity, at one concentration (the size of the read-out at that concentration, not a potency): 53%
For compound 3 the middle estimate is 13 percentage points above the measured one, within the range that was stated.
By their numbers in this assay, from the lowest: compounds 2 and 3 (each within the scatter of the next); then compound 1.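

On the amide-type nitrogen, 3-(trifluoromethyl)phenyl in place of 3,4-dichlorophenyl gives, in this assay, no change at the digits printed from compound 2 to compound 3 (within the scatter), so this assay does not separate these two outer rings at the one concentration tested. Hydrogen in place of trifluoromethyl on an aromatic carbon gives a number 27 percentage points lower from compound 1 to compound 3 (beyond the scatter), which ties the weaker effect of compound 1 to its second trifluoromethyl group, a link that the earlier pair, differing in more than one place, could not isolate. No measurement shown here explains either step.

Still open, from the compounds shown here alone, is how an outer ring with a single chlorine, a methoxy group or a nitrile would read in this assay. Also open, going by these compounds, is whether a phenyl ring with no substituent, or a morpholine on that ring, would keep the level of compound 3.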